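The compounds below may be only part of what the source reports. "The series", "measured", "known", "first", "only" and "open" are said of these compounds alone.

Of the compounds shown here, three of the shared core have been tested so far in an ADME assay on A549 cells (Homo sapiens) for cytotoxicity, read by MTT assay (a lower number here means that less compound is tolerated, a higher number that more compound is tolerated), and all three stop at the upper limit of that test. Compound 1, whose structure is `C#CCN(c1ccccc1C)S(=O)(=O)c1cc(Cl)ccc1Cl`, reaches only the limit > 5000 nM in this assay. Compound 2, with structure `CCN(c1ccc(Cl)cc1C)S(=O)(=O)c1cc(Cl)ccc1Cl`, likewise stops at the limit > 5000 nM. Compound 3, with structure `C=CCN(c1ccc(Cl)cc1C)S(=O)(=O)c1cc(Cl)ccc1Cl`, stands at the limit > 5000 nM as well. Because all three values sit at the same boundary (the limit of > 5000 nM in this assay, at which 3 of the 3 values shown sit), the step that the two limits leave unreadable from compound 2 to compound 3 cannot be read as a size. Compound 3 therefore stands at the limit of this assay, with no number of its own, alongside the other two.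

Compound 4, with structure `C#CCN(c1ccc(Cl)cc1C)S(=O)(=O)c1cc(Cl)ccc1Cl`, differs from compound 3 in one place: ethynyl in place of vinyl on a saturated chain carbon bound to a sulfonamide nitrogen. Going by the values given here, the only measured step that bears on this position, a step that the two limits leave unreadable from compound 2 to compound 3, is unreadable, so no size can be carried over. Compound 1 already carries the same propargyl chain and also stops at the limit > 5000 nM. On that basis the step that the limit leaves unreadable from compound 3 to compound 4 is expected to be none beyond the scatter. The estimate for compound 4 is 8000 nM, in the range 4000 nM to 20000 nM, most likely reported again as a limit.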

Compound 4, half-maximal cytotoxic concentration: > 5000 nM
Compound 4 was reported as a limit; the forecaster's own chance of this, stated with the estimate: 85%; the middle value is on the limit's open side.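

Compound 4 stops at > 5000 nM in this assay, and this is a limit, not a number. Its steps from compound 1, compound 2 and compound 3 cannot be read, because all four compounds sit at the same boundary: the limit of > 5000 nM in this assay, at which 4 of the 4 values shown sit. The compounds shown leave open at what concentration any of them harms these cells, and whether changing the chain on the sulfonamide nitrogen or the chloro group shifts that concentration.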